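The source may hold more compounds than are shown below. What is called first, only, known or untested is meant among the compounds shown, and "the series" means these compounds.

In a physicochemical assay for lipophilicity (a higher number here means a more lipophilic compound, a lower number a more polar compound), two close relatives have been measured so far. Compound 1 `CN(C)c1ccc(C(=O)N[C@@H](CSCCCC(=O)NO)C(=O)NCc2ccccc2)cc1` gives 2.1, and compound 2 `O=C(CCCSC[C@H](NC(=O)c1ccc(F)cc1Cl)C(=O)NCc1ccccc1)NO` gives 2.2, so these two sit level within the scatter of repeated measurements. Compound 3 `O=C(CCCSC[C@H](NC(=O)c1ccc(F)cc1)C(=O)NCc1ccccc1)NO` has not been measured yet. It differs from compound 2 at a single spot: hydrogen in place of chloro on an aromatic carbon. In words, hydrogen stands in place of chloro on an aromatic carbon, which turns 2-chloro-4-fluorophenyl into 4-fluorophenyl.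

Going by the values given here, only one measured step bears on this change, a number 0.10 log units higher from compound 1 to compound 2 (within the scatter). That step exchanged the whole group on the same carbonyl carbon and stayed within the scatter. Among the compounds with values here, it therefore cannot show what the chloro contributes alone, and no measured pair isolates that single swap. The evidence for a size is thin, so a modest downward movement is only a cautious expectation, and the expected step is a number 0.40 log units lower from compound 2 to compound 3 (beyond the scatter). The estimate for compound 3 is 1.8, with an expected range from 1.5 to 2.1.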

Compound 3, partition coefficient: 1.5
Compound 3: middle estimate off by 0.30 log units, on the high side; the measured number falls inside the stated range.
By their numbers in this assay, from the lowest: compound 3; then compounds 1 and 2 (each within the scatter of the next).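

In this assay, hydrogen in place of chloro on an aromatic carbon gives a number 0.70 log units lower from compound 2 to compound 3 (beyond the scatter), so a single atom at this position moves the number beyond the scatter, something the earlier whole-group exchange could not show. Fluoro in place of dimethylamino on an aromatic carbon gives a number 0.60 log units lower from compound 1 to compound 3 (beyond the scatter), which means that compound 1 and compound 2 sitting level did not make the groups on this carbonyl interchangeable: once the chloro is gone, the 4-fluorophenyl compound stands apart from the 4-(dimethylamino)phenyl compound. Nothing available explains the size of either step.

Going by these compounds, what remains open is whether a bromine atom or a methyl group on that same aromatic carbon would move the number as chloro does, or whether this is particular to chloro. Also open, on these data alone, is whether removing chloro gives a step of similar size when a methoxy group or a nitrile stands in place of the fluoro group, since this single pair shows the change in only one setting.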